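Trifluoromethyl for Ethyl on a Weak Aortic Inhibitor

The source may hold more compounds than are shown below. What is called first, only, known or untested is meant among the compounds shown, and "the series" means these compounds.

Measured compounds:
compound 1, `OCc1ccc(-c2nn(Cc3cncnc3)c3ccccc23)o1`: 3200 nM
compound 2, `CCCc1cnc(-c2nn(Cc3ccccc3F)c3ncccc23)nc1N`: 252000 nM

In a functional assay (aorta) with Oryctolagus cuniculus as the target (on this read-out higher numbers stand for weaker inhibition and lower numbers for stronger inhibition), compound 2 gives 252000 nM, the highest of the two numbers at hand. Compound 1 in this assay gives 3200 nM, a lower number by a gap beyond the scatter, but the two structures differ in many places, so no single change can be read from their values. Compound 3, `Nc1nc(-c2nn(Cc3ccccc3F)c3ncccc23)ncc1CC(F)(F)F`, differs from compound 2 by trifluoromethyl in place of ethyl on a saturated chain carbon bound to an aromatic carbon. Within the data shown here, no pair of measured compounds shows the effect of this kind of change on this read-out. The expected step is therefore a 1.7-fold lower number from compound 2 to compound 3 (0.23 log units; within the scatter), a modest change that may well stay within the scatter. Compound 3 is accordingly estimated at 150000 nM, in a range from 40000 nM to 600000 nM.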

Compound 3, half-maximal inhibitory concentration: 508000 nM
Compound 3: middle estimate off by 3.4-fold (0.53 log units), on the low side; the measured number falls inside the stated range.
By their numbers in this assay, from the lowest: compound 1; then compounds 2 and 3 (each within the scatter of the next).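

In this assay, putting trifluoromethyl in place of ethyl on a saturated chain carbon bound to an aromatic carbon gives a 2.0-fold higher number from compound 2 to compound 3 (0.30 log units; within the scatter). Among these compounds, this is the first single-place change on this read-out, and it shows that compound 2 and compound 3 cannot be told apart at this position, even though the entering group adds fluorine and more heavy atoms. Nothing measured here accounts for this outcome, and no supporting data on the groups or the compounds are available.

The compounds shown leave open whether an amine, a carboxylic acid or a longer chain at this place would give a number beyond the scatter from compound 2 in this assay. They also leave open whether the same change would read alike on the core of compound 1.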